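This account rests on a few compounds, and the source may have more. Where it says the series, first, only, none or still open, it means among the compounds named here.

Measured compounds in an ADME assay on MT4 cells (Homo sapiens) for cytotoxicity, read by MTT assay, with a stated time of 5 days; on this read-out higher numbers stand for lower toxicity in this test and lower numbers for higher toxicity in this test:
Compound 1 `CCCN(c1ccnc(Nc2ccc(C#N)cc2)n1)c1c(F)cc(-c2ccc(C#N)cc2)cc1F` gives 212000 nM.
Compound 2 `CCCCN(c1ccnc(Nc2ccc(C#N)cc2)n1)c1c(F)cc(-c2ccc(C#N)cc2)cc1F` gives 211000 nM.
Compound 3 `N#Cc1ccc(Nc2nccc(N(CCCO)c3c(F)cc(-c4ccc(C#N)cc4)cc3F)n2)cc1` gives 68000 nM.

Compound 3 stands lowest of the three, and both of its steps from the others lie beyond the scatter: a 3.1-fold lower number from compound 1 to compound 3 (0.49 log units; beyond the scatter) and a 3.1-fold lower number from compound 2 to compound 3 (0.49 log units; beyond the scatter). The step between the other two, a 1.0-fold lower number from compound 1 to compound 2 (0.00 log units; within the scatter), is within the scatter.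

Compound 4 `N#Cc1ccc(Nc2nccc(N(CCCF)c3c(F)cc(-c4ccc(C#N)cc4)cc3F)n2)cc1` differs from compound 3 by fluoro in place of hydroxy on a saturated chain carbon, three bonds along the chain from a nitrogen on an aromatic ring. For the measured compounds named here, no measured step exchanges hydroxy for fluoro, so the bearing steps are indirect: the two steps that introduce the hydroxy, from compound 1 and from compound 2, each brought a modest lowering of the number, while the step from hydrogen to methyl did nothing. Going by the values given here, removing the hydroxy in favour of fluoro is therefore expected to undo part or all of that lowering in this assay, giving a moderately higher number for compound 4, with the uncertainty that fluoro has no measured counterpart here. The expected step is a 2.2-fold higher number from compound 3 to compound 4 (0.34 log units; beyond the scatter); compound 4 is estimated at 150000 nM, within a range from 60000 nM to 400000 nM.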

Compound 4, half-maximal cytotoxic concentration: 241000 nM
Beside the measured number, compound 4's estimate is 1.6-fold (0.21 log units) below it; the measured number falls inside the stated range.
By their numbers in this assay, from the lowest: compound 3; then compounds 2, 1 and 4 (each within the scatter of the next).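

In this assay, fluoro in place of hydroxy on this chain carbon gives a 3.5-fold higher number from compound 3 to compound 4 (0.55 log units; beyond the scatter), so the lower number of compound 3 does not extend to every heteroatom at the end of the chain. Fluoro in place of hydrogen gives a 1.1-fold higher number from compound 1 to compound 4 (0.06 log units; within the scatter), and fluoro in place of methyl gives a 1.1-fold higher number from compound 2 to compound 4 (0.06 log units; within the scatter), which leaves compounds 1, 2 and 4 level and hydroxy as the only one of these changes that sets a compound apart at this position. Nothing available here explains why hydroxy and fluoro part in this way.

As far as these compounds go, it remains open whether an amine, a methoxy group or a carboxylic acid at this chain end would stand with hydroxy or with the other three compounds. From the compounds shown here alone, the effect of a longer chain carrying hydroxy is also open.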